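Hydrazone series: moving the ring nitrogen of the pyridyl amide

The source may report more compounds than this note shows. Statements on the series, on what has been measured and on what is new or still open speak of the compounds shown alone.

Measured so far in a functional assay on MDA-MB-231 cells (Homo sapiens) for antiproliferative activity, with a stated time of 4 days; on this read-out lower numbers stand for stronger inhibition and higher numbers for weaker inhibition:
compound 1 `CCCCc1ccc2[nH]c(-c3ccc(C(F)(F)F)cc3)c(/C=N/NC(=O)c3ccc(OC)cc3)c2c1` gives 284 nM
compound 2 `CCCCc1ccc2[nH]c(-c3ccc(C(F)(F)F)cc3)c(/C=N/NC(=O)c3ccncc3)c2c1` gives 94 nM

For the measured compounds named here, compound 2 stands lowest of the two numbers in this assay, the only other being compound 1, and the one measured step is a 3.0-fold lower number from compound 1 to compound 2 (0.48 log units; beyond the scatter). Compound 3 `CCCCc1ccc2[nH]c(-c3ccc(C(F)(F)F)cc3)c(/C=N/NC(=O)c3ccccn3)c2c1` differs from compound 2 by pyridin-2-yl in place of pyridin-4-yl on a carbonyl carbon. Going by the values given here, no measured step bears on this change; the step from compound 1 to compound 2 swaps a different group, so it does not test pyridin-2-yl against pyridin-4-yl. Compound 3 is therefore expected to stay near compound 2, with a step of a 1.4-fold higher number from compound 2 to compound 3 (0.14 log units; within the scatter), not beyond the scatter. Compound 3 is estimated at 130 nM, in the range 45 nM to 400 nM.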

Compound 3, half-maximal inhibitory concentration: 260 nM
Compound 3: the middle estimate sits 2.0-fold (0.30 log units) below what was measured; the range from low to high includes it.
By their numbers in this assay, from the lowest: compound 2; then compounds 3 and 1 (each within the scatter of the next).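

In this assay, the place of the ring nitrogen matters on this carbonyl carbon: the change to pyridin-2-yl gives a 2.8-fold higher number from compound 2 to compound 3 (0.44 log units; beyond the scatter) even though the two groups have the same atoms. The gain over 4-methoxyphenyl therefore belongs to pyridin-4-yl alone, since pyridin-2-yl gives a 1.1-fold lower number from compound 1 to compound 3 (0.04 log units; within the scatter) and does not separate from compound 1. No available evidence accounts for this difference. From the compounds shown here alone, it remains open where pyridin-3-yl would fall, and whether an amino group on the pyridin-4-yl ring would keep the number of compound 2.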